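Hydroxymethyl to ethyl on the piperidine of compound 3

The compounds below may be only part of what the source reports. "The series", "measured", "known", "first", "only" and "open" are said of these compounds alone.

Compound 3 `CC(C)(C)c1ccc(C(=O)N2CCC3(CC2)C(=O)N(CC(=O)N2CCCC(CO)C2)CN3c2ccccc2)cc1` gives 8200 nM in an assay on HEK293 cells for displacement of a labelled ligand from NPC1-like intracellular cholesterol transporter 1 (Homo sapiens) (a lower number here means a stronger inhibitor, a higher number a weaker inhibitor), the second highest of the three numbers. Compound 1 `CC(C)(C)c1ccc(C(=O)N2CCC3(CC2)C(=O)N(CC(=O)NCCO)CN3c2ccccc2)cc1` gives 1000 nM, and compound 2 `CC1CCCN(C(=O)CN2CN(c3ccccc3)C3(CCN(C(=O)c4ccc(C(C)(C)C)cc4)CC3)C2=O)C1` gives 12000 nM; the step of an 8.2-fold higher number from compound 1 to compound 3 (0.91 log units; beyond the scatter) lies beyond the scatter. Compound 4 `CCC1CCCN(C(=O)CN2CN(c3ccccc3)C3(CCN(C(=O)c4ccc(C(C)(C)C)cc4)CC3)C2=O)C1` differs from compound 3 by methyl in place of hydroxy on a saturated chain carbon bound to a saturated ring carbon. For the measured compounds named here, the only measured step at the same place, a 1.5-fold lower number from compound 2 to compound 3 (0.17 log units; within the scatter), swapped hydrogen for hydroxy and stayed within the scatter. Taking the hydroxy away again, now with methyl in its stead, is therefore expected to leave this assay essentially unchanged, with a 1.3-fold higher number from compound 3 to compound 4 (0.13 log units; within the scatter), a number close to that of compound 2. Compound 4 is estimated at 11000 nM, within 4000 nM to 30000 nM.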

Compound 4, half-maximal inhibitory concentration: 3900 nM
Estimate against measurement, compound 4: 2.8-fold (0.45 log units) above; the whole stated range lies above it.
By their numbers in this assay, from the lowest: compound 1; then compound 4; then compounds 3 and 2 (each within the scatter of the next).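

In this assay, for the compounds shown here, the 3-ethylpiperidin-1-yl amide is the first piperidine here to separate from the others, with a 2.1-fold lower number from compound 3 to compound 4 (0.32 log units; beyond the scatter) and a 3.1-fold lower number from compound 2 to compound 4 (0.49 log units; beyond the scatter), whereas adding hydroxy to the methyl had stayed within the scatter. This place on the piperidine therefore does respond to its substituent, though not to every change, and the piperidines do not fully match the open-chain amide, with a 3.9-fold higher number from compound 1 to compound 4 (0.59 log units; beyond the scatter). Nothing available here accounts for the difference between ethyl and hydroxymethyl.

The compounds shown leave open whether the trend continues with a longer chain such as propyl, or changes with an amine at the end of the chain. From the compounds shown here alone, whether any such piperidine could reach the number of compound 1 also remains unknown.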